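Selenium to Sulfur on a Shared Core

The source may report more compounds than this note shows. Statements on the series, on what has been measured and on what is new or still open speak of the compounds shown alone.

The measured compounds and their numbers in a functional assay on P388 cells (Mus musculus) for antiproliferative activity, with a stated time of 72 h; a lower number here means a stronger inhibitor, a higher number a weaker inhibitor:

Compound 1, `CSc1cnc2ccccc2c1[Se]CC#CCO`: 2.6 ug/mL
Compound 2, `CSc1cnc2ccccc2c1[Se]CC#CCOC(=O)c1ccccc1`: 3.5 ug/mL
Compound 3, `OCC#CCSc1cnc2ccccc2c1Cl`: 2.4 ug/mL

Compound 1 holds the second highest of the three numbers in this assay. Its nearest neighbour is compound 3, and its furthest is compound 2; both lie within the scatter of compound 1, so the three values cannot be put in order.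

The compound still to be measured is compound 4, `CSc1cnc2ccccc2c1SCC#CCO`. It differs from compound 1 in one place: a group of 6 heavy atoms (4 carbon, 1 oxygen, 1 sulfur; no ring) in place of a group of 6 heavy atoms (4 carbon, 1 oxygen, 1 selenium; no ring), on an aromatic carbon.

Going by the values given here, only one step is known between measured compounds, a 1.3-fold higher number from compound 1 to compound 2 (0.13 log units; within the scatter), and it concerns the far end of the chain, not the atom that links the chain to the core. Among the compounds with values here, no measured pair shows the selenium-to-sulfur exchange on its own; compound 3 carries a sulfur-linked chain, but it also differs from compound 1 in a second place. The value of compound 1 and the value of compound 3, 2.4 ug/mL, only show that the two numbers sit within the scatter of each other. Nothing in the data points to a change beyond the scatter, so compound 4 is expected to give about 2.6 ug/mL, within 1.3 ug/mL to 5.2 ug/mL, which means an expected step of no change at the digits printed from compound 1 to compound 4 (within the scatter).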

Compound 4, concentration for 50% inhibition: 3.1 ug/mL
Compound 4: the middle estimate sits 1.2-fold (0.08 log units) below what was measured; the measured number falls inside the stated range.
By their numbers in this assay, from the lowest: compounds 3, 1, 4 and 2 (each within the scatter of the next).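

The exchange of the selenium-linked chain for the sulfur-linked chain, on the aromatic carbon opposite the ring nitrogen and with the methylsulfanyl group left in place, can now be read on its own in this assay: it gives a 1.2-fold higher number from compound 1 to compound 4 (0.08 log units; within the scatter). Going by these compounds alone, compound 3 also carries a sulfur-linked chain but differs from compound 1 in a second place, so this pair is the first to isolate the linking atom, and at this position selenium and sulfur give numbers that cannot be told apart. Nothing measured here offers an explanation for how close the two numbers lie.

The compounds shown leave open whether selenium and sulfur would also stay within the scatter of each other with the benzoyl ester at the far end of the chain, or with an amine in place of the methylsulfanyl group on the shared core. They also leave open whether a linking oxygen or a linking methylene at this aromatic carbon would give a number close to those of the selenium and sulfur links.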